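This account rests on a few compounds, and the source may have more. Where it says the series, first, only, none or still open, it means among the compounds named here.

Measured so far:
compound 1 `Cn1ccnc1NC(=O)c1cccc(Nc2ncc(F)c(Nc3ccc(F)cc3)n2)c1` — 13100 nM in a functional assay on KBVIN cells (Homo sapiens) for antiproliferative activity, read by sulforhodamine B assay, with a stated time of 3 days; on this read-out lower numbers stand for stronger inhibition of growth and higher numbers for weaker inhibition of growth
compound 2 `COCC(=O)Nc1cccc(Nc2ncc(F)c(Nc3ccc(F)cc3)n2)c1` — 3940 nM

Within this pair compound 1 gives the highest number, with compound 2 as its only neighbour; the change between them is a 3.3-fold lower number from compound 1 to compound 2 (0.52 log units; beyond the scatter), a modest step beyond the scatter.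

Compound 3 `CN1CCC(C(=O)Nc2cccc(Nc3ncc(F)c(Nc4ccc(F)cc4)n3)c2)CC1` is not yet measured. It differs from compound 1 in one place: ((1-methylpiperidin-4-yl)carbonyl)amino in place of (1-methyl-1H-imidazol-2-yl)carbamoyl on an aromatic carbon.

Within the data shown here, the one measured step that bears on this change is that from compound 1 to compound 2, where a ((methoxymethyl)carbonyl)amino group likewise replaced the (1-methyl-1H-imidazol-2-yl)carbamoyl group at the same aromatic carbon and gave a modest lowering of the number. Compound 3 carries a different acylamino group, so the step is only a loose guide. For compound 3 a step of similar size and direction is expected, a 2.9-fold lower number from compound 1 to compound 3 (0.46 log units; beyond the scatter), giving an estimate of 4500 nM with a range from 1500 nM to 13000 nM.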

Compound 3, concentration for 50% growth inhibition: 11900 nM
Compound 3: the middle estimate sits 2.6-fold (0.42 log units) below what was measured; the measured number falls inside the stated range.
By their numbers in this assay, from the lowest: compound 2; then compounds 3 and 1 (each within the scatter of the next).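

In this assay, the step from the imidazolyl amide to the ((1-methylpiperidin-4-yl)carbonyl)amino group is a 1.1-fold lower number from compound 1 to compound 3 (0.04 log units; within the scatter), so an acylamino group on this aromatic carbon does not by itself give the lower number seen with compound 2. With the acylamino link kept, 1-methylpiperidin-4-yl in place of methoxymethyl on the carbonyl carbon gives a 3.0-fold higher number from compound 2 to compound 3 (0.48 log units; beyond the scatter), which shows that the group on that carbonyl carbon matters at this position. Nothing on hand explains this difference.

The compounds shown leave open whether an acetyl group or a longer methoxyethyl chain on the same carbonyl carbon would fall nearer compound 2 or compound 3. As far as these compounds go, it also remains open whether a piperidine with an unsubstituted ring nitrogen would match compound 3.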